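The compounds below may be only part of what the source reports. "The series", "measured", "known", "first", "only" and "open" are said of these compounds alone.

Working notes on the amide series.

The shared core carries a nitrile and two indole-bearing units, and the three measured compounds differ only in the aryl group on the carbonyl carbon. Compound 1 `CN1[C@@H]2c3[nH]c4ccccc4c3C[C@H]1[C@H](C#N)N1[C@@H](CNC(=O)c3cccc(C(F)(F)F)c3)c3[nH]c4ccccc4c3C[C@@H]21` gives 340 nM in a functional assay on HepG2 cells (Homo sapiens) for cytotoxicity, read by MTT assay, with a stated time of 72 h; a higher number here means a weaker inhibitor, a lower number a stronger inhibitor. Compound 2 `CN1[C@@H]2c3[nH]c4ccccc4c3C[C@H]1[C@H](C#N)N1[C@@H](CNC(=O)c3ccc(Cl)cc3)c3[nH]c4ccccc4c3C[C@@H]21` gives 350 nM in this assay, and compound 3 `CN1[C@@H]2c3[nH]c4ccccc4c3C[C@H]1[C@H](C#N)N1[C@@H](CNC(=O)c3cccc4c3CCCC4)c3[nH]c4ccccc4c3C[C@@H]21` gives 540 nM. The steps between them are a 1.0-fold higher number from compound 1 to compound 2 (0.01 log units; within the scatter), a 1.6-fold higher number from compound 1 to compound 3 (0.20 log units; within the scatter) and a 1.5-fold higher number from compound 2 to compound 3 (0.19 log units; within the scatter). Compound 3 thus holds the highest of the three numbers, yet its distance to compound 2 and to compound 1 stays within the scatter, so the three aryl groups are not told apart by this assay.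

Compound 4 `CN1[C@@H]2c3[nH]c4ccccc4c3C[C@H]1[C@H](C#N)N1[C@@H](CNC(=O)c3ccc4ccccc4c3)c3[nH]c4ccccc4c3C[C@@H]21` is the next member; the change is naphthalen-2-yl in place of 1,2,3,4-tetrahydronaphthalen-5-yl on a carbonyl carbon. The two steps that bear on it, a 1.6-fold higher number from compound 1 to compound 3 (0.20 log units; within the scatter) and a 1.5-fold higher number from compound 2 to compound 3 (0.19 log units; within the scatter), are also swaps of one aryl group for another on the same carbonyl carbon, and neither moved beyond the scatter. No step beyond the scatter is therefore expected for compound 4 in this assay; the expected step is a 1.2-fold lower number from compound 3 to compound 4 (0.08 log units; within the scatter).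

Compound 4 is estimated at 450 nM in this assay, with an expected range from 200 nM to 1000 nM.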

Compound 4, half-maximal inhibitory concentration: 1210 nM
Estimate against measurement, compound 4: 2.7-fold (0.43 log units) below, outside the stated range (above it).
By their numbers in this assay, from the lowest: compounds 1, 2 and 3 (each within the scatter of the next); then compound 4.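

In this assay, the aryl group on this carbonyl carbon is no longer without effect: the naphthalen-2-yl of compound 4 gives a 2.2-fold higher number from compound 3 to compound 4 (0.35 log units; beyond the scatter) and also a 3.5-fold higher number from compound 2 to compound 4 (0.54 log units; beyond the scatter) and also a 3.6-fold higher number from compound 1 to compound 4 (0.55 log units; beyond the scatter) in this series, whereas the swaps among the other three aryl groups all stayed within the scatter. Compound 4 is therefore the weakest inhibitor of the four, and it is set apart even from compound 3, whose 1,2,3,4-tetrahydronaphthalen-5-yl group has the same count of 10 carbon heavy atoms, with no hydrogen-bond donors or acceptors and no net charge on either side, so these counts alone do not decide the outcome at this position. Nothing measured here bears on the reason for this step.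

The step from compound 3 to compound 4 changes both the second ring, from non-aromatic to aromatic, and the point of attachment, so a naphthalen-1-yl group on the same carbonyl carbon is what would separate the two changes. From the compounds shown here alone, how this position responds to an aryl group carrying an amine or a carboxylic acid also remains open.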